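This account rests on a few compounds, and the source may have more. Where it says the series, first, only, none or still open, it means among the compounds named here.

Working notes on the series.

Compound 1 `COc1ccc2[nH]c(=O)c(-c3nc4cc(C)c(C)cc4[nH]3)cc2c1` and compound 2 `Cc1ccc2[nH]c(=O)c(-c3nc4cc(C)c(C)cc4[nH]3)cc2c1` share one core and differ only in a single substituent; compound 3 `Cc1ccc2[nH]c(=O)c(-c3nc4cc(Br)ccc4[nH]3)cc2c1` carries a different core, and the difference between the two cores is not broken down here. Compound 4 `COc1ccc2[nH]c(=O)c(-c3nc4cc(Br)ccc4[nH]3)cc2c1` is the not yet measured partner of compound 3.

In a functional assay on NCI-H460 cells (Homo sapiens) for cytotoxicity, read by MTT assay, with a stated time of 48 h (on this read-out higher numbers stand for weaker inhibition and lower numbers for stronger inhibition), compound 1 gives > 100000 nM, which is a limit of the assay and not a number. In this assay compound 2 gives > 100000 nM, again a limit. In this assay compound 3 gives > 100000 nM, also a limit. The change from compound 2 to compound 1 is methoxy in place of methyl on an aromatic carbon, and its step that the two limits leave unreadable from compound 2 to compound 1 cannot be sized because of the limit of > 100000 nM in this assay, at which 3 of the 3 values shown sit.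

The change from compound 3 to compound 4 is methoxy in place of methyl on an aromatic carbon. Its place reads the same, word for word, as the place of the change from compound 2 to compound 1, so it is the same change on a different core.

Expectation for compound 4: since the only measured example of this change sits between two limits, and since every value shown sits at the same limit, compound 4 is expected to remain at that limit, so the estimated step that the limit leaves unreadable from compound 3 to compound 4 from compound 3 to compound 4 is taken as no readable movement. The estimate for compound 4 in this assay is 200000 nM, with a range from 50000 nM to 1000000 nM, and the result is most likely to be reported only as a limit.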

Compound 4, half-maximal inhibitory concentration: > 100000 nM
Compound 4 ended at the assay's limit; the forecaster's own chance of this, stated with the estimate: 85%; the middle value does not contradict the limit.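

No new step can be read: the change from compound 3 to compound 4, methoxy in place of methyl on an aromatic carbon, cannot be sized in this assay because both compounds sit at a limit of the assay, not at a number: the limit of > 100000 nM in this assay, at which 4 of the 4 values shown sit.

The compounds shown leave open whether methoxy in place of methyl, or the difference between the two cores, has any effect in this assay.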